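Propylsulfonyl to methylsulfonyl on compound 2

The source may report more compounds than this note shows. Statements on the series, on what has been measured and on what is new or still open speak of the compounds shown alone.

- compound 1 `CCCS(=O)(=O)c1cccc(C#Cc2cc(Cl)ccc2OCC(=O)O)c1` gives 5760 ng.h/mL
- compound 2 `CCCS(=O)(=O)c1ccc(F)c(C#Cc2cc(Cl)ccc2OCC(=O)O)c1` gives 6140 ng.h/mL

In an ADME assay on the whole organism (plasma, strain BALB/c) for pharmacokinetics, with Mus musculus as the target, at a dose of 5 mg/kg by the oral route (on this read-out lower numbers stand for lower exposure and higher numbers for higher exposure at the dose given), compound 2 stands at 6140 ng.h/mL and sits within the scatter of compound 1. Compound 3 `CS(=O)(=O)c1ccc(F)c(C#Cc2cc(Cl)ccc2OCC(=O)O)c1` follows from compound 2 by hydrogen in place of ethyl on a saturated chain carbon bound to a sulfonyl sulfur with hydrogen in place of ethyl on a saturated chain carbon bound to a sulfonyl sulfur. Going by the values given here, the only measured step of a 1.1-fold higher number from compound 1 to compound 2 (0.03 log units; within the scatter) is a fluoro change and lies within the scatter. Among the compounds with values here, no measured step touches the sulfonyl chain, so no step beyond the scatter is expected, with wide uncertainty. The expected step is a 1.2-fold lower number from compound 2 to compound 3 (0.09 log units; within the scatter) in this assay as estimated. Compound 3 is expected at 5000 ng.h/mL with an estimated range of 2200 ng.h/mL to 11000 ng.h/mL for now.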

Compound 3, area under the concentration-time curve: 3240 ng.h/mL
Beside the measured number, compound 3's estimate is 1.5-fold (0.19 log units) above it; measured number inside the range.
By their numbers in this assay, from the lowest: compounds 3, 1 and 2 (each within the scatter of the next).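

In this assay, the sulfonyl chain now has its first measured step: propylsulfonyl to methylsulfonyl gives a 1.9-fold lower number from compound 2 to compound 3 (0.28 log units; within the scatter). For this pair, then, oral exposure does not separate propyl from methyl beyond the scatter, even with ethyl gone from the saturated chain carbon bound to a sulfonyl sulfur. No measurement available here bears on the reason for this result.

Still open, on these data alone, is whether a longer chain, such as butyl, or an amine on the sulfonyl sulfur would stay within the scatter. Also open, as far as these compounds go, is how methylsulfonyl reads on the core of compound 1, without the fluoro.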